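The source may hold more compounds than are shown below. What is called first, only, known or untested is meant among the compounds shown, and "the series" means these compounds.

Measured so far in an assay on CHO cells for antagonist activity at transient receptor potential cation channel subfamily V member 1 (Homo sapiens), read by FLIPR and calcium flux; on this read-out higher numbers stand for weaker inhibition and lower numbers for stronger inhibition:
compound 1 `CCCCCCc1nc(C(F)(F)F)ccc1CNC(=O)C(C)c1ccc(NS(C)(=O)=O)c(F)c1` gives 1.6 nM
compound 2 `CCC1CCC(c2nc(C(F)(F)F)ccc2CNC(=O)[C@@H](C)c2ccc(NS(C)(=O)=O)c(F)c2)CC1` gives 0.2 nM

Compound 1 has the higher of the two numbers; compound 2 sits beyond the scatter below it. Compound 3 `CC(C(=O)NCc1ccc(C(F)(F)F)nc1C1CC2CCC1C2)c1ccc(NS(C)(=O)=O)c(F)c1` is not yet measured. Against compound 1 the change is a group of 7 heavy atoms (7 carbon; 2 five-membered non-aromatic rings of carbon only) in place of a group of 6 heavy atoms (6 carbon; no ring), on an aromatic carbon, in words a group of 7 heavy atoms (7 carbon; 2 five-membered non-aromatic rings of carbon only) in place of a group of 6 heavy atoms (6 carbon; no ring), on an aromatic carbon. A step toward a lower number is expected, a 3.2-fold lower number from compound 1 to compound 3 (0.51 log units; beyond the scatter), because compound 2 with its ring group gives 0.2 nM. Compound 3 is estimated at 0.5 nM, range 0.15 nM to 1.6 nM.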

Compound 3, inhibition constant: 1.5 nM
Compound 3: middle estimate off by 3.0-fold (0.48 log units), on the low side; low and high end bracket the measured number.
By their numbers in this assay, from the lowest: compound 2; then compounds 3 and 1 (each within the scatter of the next).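

In this assay the group of 7 carbon atoms with 2 five-membered non-aromatic rings of carbon only, in place of hexyl on the aromatic carbon next to the ring nitrogen, gives a 1.1-fold lower number from compound 1 to compound 3 (0.03 log units; within the scatter) with no separation between the two. This position therefore takes this ring-bearing, all-carbon group and the open hexyl chain without a difference that can be read. Nothing measured here bears on why.

As far as these compounds go, whether a shorter chain such as butyl, or an amine or ether at this position, would read alike remains open.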